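The compounds below may be only part of what the source reports. "The series", "measured", "known", "first", "only" and "open" are said of these compounds alone.

Compound 1 `Cc1ccc(Cn2cc(COc3ccc4c(=O)ccoc4c3)nn2)cc1`: in a functional assay on HeLa cells (Homo sapiens) for cytotoxicity, read by MTT assay, with a stated time of 48 h (a higher number here means a weaker inhibitor, a lower number a stronger inhibitor), compound 1 gives > 100000 nM, which is a limit of the assay and not a number.
Compound 2 `O=c1ccoc2cc(OCc3cn(Cc4ccc([N+](=O)[O-])cc4)nn3)ccc12`: in this assay compound 2 gives 25700 nM.
Compound 3 `O=c1ccoc2cc(OCc3cn(Cc4cccc(Br)c4)nn3)ccc12`: in this assay compound 3 gives > 100000 nM, again a limit rather than a number.

Within the data shown here, compound 2 therefore holds the only real number among the three, the other two values sitting at the limit of > 100000 nM in this assay, at which 2 of the 3 values shown sit. Compound 4 `O=c1ccoc2cc(OCc3cn(Cc4ccccc4Cl)nn3)ccc12` differs from compound 2 in one place: 2-chlorophenyl in place of 4-nitrophenyl on a saturated chain carbon bound to an aromatic nitrogen. The step that bears most directly on this is an at least 3.8-fold higher number from compound 2 to compound 3 (0.59 log units; beyond the scatter), where the nitro-bearing ring likewise gave way to a halogen-bearing one. Among the measured compounds shown here, the step of an at least 3.8-fold lower number from compound 1 to compound 2 (0.59 log units; beyond the scatter) points the same way: the nitro group entering brought the only measurable number. Exchanging it for 2-chlorophenyl is therefore expected to push compound 4 back toward a weaker result, most likely at the limit again. Compound 4 is estimated at 90000 nM, within 25000 nM to 300000 nM, an expected step of a 3.5-fold higher number from compound 2 to compound 4 (0.54 log units; beyond the scatter).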

Compound 4, half-maximal inhibitory concentration: > 100000 nM
Compound 4 gave a limit, no number (the forecaster's own chance of this, stated with the estimate: 60%); middle value at least 1.1-fold (0.04 log units) away from the limit.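

The change from 4-nitrophenyl to 2-chlorophenyl gives an at least 3.8-fold higher number from compound 2 to compound 4 (0.59 log units; beyond the scatter), so 2-chlorophenyl, like 3-bromophenyl, loses the measurable number seen with compound 2. Compound 4 gives a limit of the assay and not a number, and the steps to it from compound 1 and compound 3 cannot be read. In this assay, 4-nitrophenyl remains the only group shown here that gives a real number, while the other compounds share one limit: the limit of > 100000 nM in this assay, at which 3 of the 4 values shown sit.

As far as these compounds go, what a 4-chlorophenyl or 4-aminophenyl group would give on this saturated chain carbon remains open. The compounds shown therefore cannot separate the nitro group itself from where it sits on the ring.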